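Changing the aryl group on an aromatic nitrogen

The source may report more compounds than this note shows. Statements on the series, on what has been measured and on what is new or still open speak of the compounds shown alone.

Measured compounds in a functional assay on PC-3 cells (Homo sapiens) for cytotoxicity, read by MTT assay, with a stated time of 72 h; on this read-out lower numbers stand for stronger inhibition and higher numbers for weaker inhibition:
- compound 1, `Cc1cc(=O)n(-c2cccc(F)c2)nc1C(=O)Nc1ccc(Oc2ncnc3[nH]ccc23)c(F)c1`: 6680 nM
- compound 2, `Cc1ccc(-n2nc(C(=O)Nc3ccc(Oc4ncnc5[nH]ccc45)c(F)c3)c(C)cc2=O)cc1`: 20400 nM
- compound 3, `Cc1cc(=O)n(-c2ccc(Br)cc2F)nc1C(=O)Nc1ccc(Oc2ncnc3[nH]ccc23)c(F)c1`: 13300 nM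

Compound 3 has the second highest number of the three; its gaps to compound 2 and compound 1 are within scatter. Compound 4, `Cc1cc(=O)n(-c2cccc(C(F)(F)F)c2)nc1C(=O)Nc1ccc(Oc2ncnc3[nH]ccc23)c(F)c1`, differs from it by 3-(trifluoromethyl)phenyl in place of 4-bromo-2-fluorophenyl on an aromatic nitrogen. Of the steps seen, a 3.1-fold higher number from compound 1 to compound 2 (0.48 log units; beyond the scatter) is the only one beyond scatter; a 2.0-fold higher number from compound 1 to compound 3 (0.30 log units; within the scatter) and a 1.5-fold lower number from compound 2 to compound 3 (0.19 log units; within the scatter) are not. The aryl group therefore shifts this assay only a little. The nearest comparison is compound 1, whose 3-fluorophenyl gives 6680 nM. Compound 4 is expected at 10000 nM, within 4000 nM to 25000 nM, meaning an estimated 1.3-fold lower number from compound 3 to compound 4 (0.12 log units; within the scatter).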

Compound 4, half-maximal inhibitory concentration: 15600 nM
Compound 4: middle estimate off by 1.6-fold (0.19 log units), on the low side, within the range that was stated.
By their numbers in this assay, from the lowest: compounds 1, 3, 4 and 2 (each within the scatter of the next, the first and the last beyond it).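

Compound 4 adds a third substituted aryl group that stays close to two others in this assay, with a 1.2-fold higher number from compound 3 to compound 4 (0.07 log units; within the scatter) and a 1.3-fold lower number from compound 2 to compound 4 (0.12 log units; within the scatter) as its steps. Trifluoromethyl in place of fluoro on the aromatic carbon does register, with a 2.3-fold higher number from compound 1 to compound 4 (0.37 log units; beyond the scatter) as a modest step, so 3-fluorophenyl now stands apart from two of the other aryl groups, though not from the one in compound 3. Nothing available explains these steps.

From the compounds shown here alone, whether an amine or a carboxylic acid on the phenyl ring, or a pyridine ring in its place, would move the number further remains open.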